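The source may report more compounds than this note shows. Statements on the series, on what has been measured and on what is new or still open speak of the compounds shown alone.

Measured in a functional assay (ileum) with Cavia porcellus as the target; on this read-out lower numbers stand for tighter binding and higher numbers for weaker binding:

- compound 1 `CCN(C)CC#CCN1C(=O)CCC1C`: 1800 nM
- compound 2 `CCN(CC)CC#CCN1C(=O)CCC1C`: 1100 nM
- compound 3 `CC1CCC(=O)N1CC#CCN(C)C`: 4300 nM

In this assay, compound 3 has the highest number of the three, so it binds the most weakly. The next compound, compound 4 `CC1CCC(=O)N1CC#CCN1CCC1`, has not been measured. It differs from compound 3 by one change, azetidin-1-yl in place of dimethylamino on a saturated chain carbon bound to a triple-bonded carbon.

Two measured steps change the same amine. The first is a 2.4-fold higher number from compound 1 to compound 3 (0.38 log units; beyond the scatter), with hydrogen in place of methyl on a saturated chain carbon bound to an amine nitrogen. The second is a 3.9-fold higher number from compound 2 to compound 3 (0.59 log units; beyond the scatter), with dimethylamino in place of diethylamino. Both are modest, and both end at compound 3 with a higher number. The remaining step, a 1.6-fold lower number from compound 1 to compound 2 (0.21 log units; within the scatter), stays within the scatter.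

Among the compounds with values here, none of the measured compounds has a ring on this nitrogen, so these steps are only a rough guide. Read in reverse, they suggest that leaving dimethylamino could lower the number somewhat. The expected change is a 2.2-fold lower number from compound 3 to compound 4 (0.33 log units; beyond the scatter), a modest step close to the edge of the scatter. Compound 4 is estimated at 2000 nM, with an expected range from 700 nM to 6500 nM.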

Compound 4, dissociation constant: 520 nM
Compound 4: the middle estimate sits 3.8-fold (0.59 log units) above what was measured; the whole stated range lies above it.
By their numbers in this assay, from the lowest: compound 4; then compounds 2 and 1 (each within the scatter of the next); then compound 3.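

In this assay, tying the amine's two chains into the four-membered ring of azetidin-1-yl produces the largest step yet seen at this place on a saturated chain carbon bound to a triple-bonded carbon (an 8.3-fold lower number from compound 3 to compound 4 (0.92 log units; beyond the scatter)). The ring's number is also lower than those of the two open-chain amines with longer chains (a 2.1-fold lower number from compound 2 to compound 4 (0.33 log units; beyond the scatter); a 3.5-fold lower number from compound 1 to compound 4 (0.54 log units; beyond the scatter)), so compound 4 binds the most tightly of the four, and the small differences among the open-chain amines gave no sign that this place could yield a step of this size. Nothing measured here explains why the ring has this result.

Compound 4 is the only ring amine among these compounds, so one result cannot show how the number depends on ring size. Pyrrolidin-1-yl and piperidin-1-yl, the rings with one and two more carbons, could lower the number further or raise it again, and morpholin-4-yl would show what an oxygen in the ring does at this place.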